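Compound 3 to compound 4: end-group swap

A few compounds are considered here, and "the series" means these few. Any claim that something is new, unique, unknown or untested is made for them only; others in the source may bear on it.

In a functional assay on Gurav cells (Homo sapiens) for inhibition, read by sulforhodamine B assay (on this read-out lower numbers stand for stronger inhibition of growth and higher numbers for weaker inhibition of growth), compound 3 `Oc1cccc2[nH]c(-c3ccc(-c4ccc(-c5ccc(C(F)(F)F)cc5)cc4)cc3)nc12` gives 3190 nM. Compound 1 `Cc1ccc2[nH]c(-c3ccc(-c4ccc(-c5cccc(Cl)c5)cc4)cc3)nc2c1` gives 2120 nM, within the scatter of compound 3. Compound 2 `FC(F)(F)c1ccc(-c2ccc(-c3ccc(-c4nc5ccccc5[nH]4)cc3)cc2)cc1` gives 39100 nM. Compound 4 `COc1ccc(-c2ccc(-c3ccc(-c4nc5c(O)cccc5[nH]4)cc3)cc2)cc1OC` differs from compound 3 by 3,4-dimethoxyphenyl in place of 4-(trifluoromethyl)phenyl on an aromatic carbon, with 3,4-dimethoxyphenyl in place of 4-(trifluoromethyl)phenyl. Within the data shown here, the only measured step, a 12-fold lower number from compound 2 to compound 3 (1.09 log units; beyond the scatter), is large, but it puts hydroxy in place of hydrogen at a different site and sets no size for this swap. Among the measured compounds shown here, compound 1 differs from compound 3 in more than one place, so it gives no clean step either. For the measured compounds named here, with no direct precedent, the expected change in this assay is a 1.3-fold lower number from compound 3 to compound 4 (0.11 log units; within the scatter), with no step beyond the scatter expected. For compound 4 the estimated value is 2500 nM, with an expected range of 700 nM to 9000 nM.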

Compound 4, concentration for 50% growth inhibition: 1110 nM
Compound 4: middle estimate off by 2.3-fold (0.35 log units), on the high side, within the range that was stated.
By their numbers in this assay, from the lowest: compounds 4, 1 and 3 (each within the scatter of the next, the first and the last beyond it); then compound 2.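

Among these compounds, with the hydroxy-bearing core held constant in this assay, 3,4-dimethoxyphenyl in place of 4-(trifluoromethyl)phenyl gives a 2.9-fold lower number from compound 3 to compound 4 (0.46 log units; beyond the scatter) as the first clean reading at this end group. The end group therefore affects the read-out, and 4-(trifluoromethyl)phenyl is not required for the activity of compound 3. Nothing available explains the direction of this step.

On these data alone, whether the two methoxy groups contribute jointly or singly remains open. Also open, as far as these compounds go, is how an amine or a carboxylic acid at this place would compare.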